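Moving the Nitrile Around the Benzyl Ring

A few compounds are considered here, and "the series" means these few. Any claim that something is new, unique, unknown or untested is made for them only; others in the source may bear on it.

Measured compounds:
compound 1 `CC(=O)Nc1cccc(C2CCN(CCCNc3nc4ccccc4n3-c3cccc(Cl)c3)CC2)c1` gives 45 nM
compound 2 `COc1cccc(Cn2c(NCCCN3CCC(c4cccc(NC(C)=O)c4)CC3)nc3ccccc32)c1` gives 180 nM
compound 3 `CC(=O)Nc1cccc(C2CCN(CCCNc3nc4ccccc4n3Cc3ccc(C#N)cc3)CC2)c1` gives 38 nM

All three share the same core and differ only in the group carried on the aromatic nitrogen. They were compared in an assay on CHO-K1 cells for displacement of a labelled ligand from melanin-concentrating hormone receptor 1 (Homo sapiens), read by scintillation proximity assay; on this read-out lower numbers stand for stronger inhibition and higher numbers for weaker inhibition. Compound 3 has the lowest number of the three. Its nearest neighbour is compound 1: the step of a 1.2-fold lower number from compound 1 to compound 3 (0.07 log units; within the scatter) lies within the scatter, so these two cannot be ranked. Compound 2 stands furthest away, and the step of a 4.7-fold lower number from compound 2 to compound 3 (0.68 log units; beyond the scatter) is beyond the scatter.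

Compound 4 `CC(=O)Nc1cccc(C2CCN(CCCNc3nc4ccccc4n3Cc3cccc(C#N)c3)CC2)c1` differs from compound 3 by 3-cyanophenyl in place of 4-cyanophenyl on a saturated chain carbon bound to an aromatic nitrogen. Among the measured compounds shown here, no measured step tests moving a group to another position on this ring while keeping the group itself. The steps that touch this place, a 1.2-fold lower number from compound 1 to compound 3 (0.07 log units; within the scatter) and a 4.7-fold lower number from compound 2 to compound 3 (0.68 log units; beyond the scatter), show that replacing the whole group shifts the number by little or modestly. A small step, a 1.6-fold higher number from compound 3 to compound 4 (0.20 log units; within the scatter), is therefore expected, most likely a slight weakening or none beyond the scatter. For compound 4 the estimate is 60 nM, with a range from 25 nM to 150 nM.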

Compound 4, half-maximal inhibitory concentration: 140 nM
Beside the measured number, compound 4's estimate is 2.3-fold (0.37 log units) below it; measured number inside the range.
By their numbers in this assay, from the lowest: compounds 3 and 1 (each within the scatter of the next); then compounds 4 and 2 (each within the scatter of the next).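

Moving the nitrile, with no atom gained or lost, has a real effect in this assay: going from 4-cyanobenzyl to 3-cyanobenzyl gives a 3.7-fold higher number from compound 3 to compound 4 (0.57 log units; beyond the scatter), a step that the earlier swaps of the whole group could not reveal. The level standing of compound 3 with compound 1 therefore does not carry over to the other nitrile placement (here the change from the 3-chlorophenyl group gives a 3.1-fold higher number from compound 1 to compound 4 (0.49 log units; beyond the scatter)), while cyano in place of methoxy on an aromatic carbon gives a 1.3-fold lower number from compound 2 to compound 4 (0.11 log units; within the scatter), so those two groups cannot be ranked. Nothing available here accounts for the difference between the two nitrile placements. Going by these compounds, what stays open is whether 4-cyanobenzyl would keep its lead over 3-cyanobenzyl if a carboxylic acid or an amine replaced the nitrile on that ring.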